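Swapping the aryl group on the ether of an amino acid core

The source may hold more compounds than are shown below. What is called first, only, known or untested is meant among the compounds shown, and "the series" means these compounds.

Measured compounds:
Compound 1, `N[C@]1(C(=O)O)[C@H]2[C@@H](C[C@H]1OCc1cccc(Br)c1)[C@]2(F)C(=O)O`: 4.71 nM
Compound 2, `N#Cc1cccc(CO[C@@H]2C[C@@H]3[C@H]([C@]2(N)C(=O)O)[C@@]3(F)C(=O)O)c1`: 2.94 nM
Compound 3, `N[C@]1(C(=O)O)[C@H]2[C@@H](C[C@H]1OCc1c(F)cccc1F)[C@]2(F)C(=O)O`: 7.02 nM

The three measured compounds share one core and differ only in the aromatic group attached through the ether. In an assay on CHO cells for binding affinity to metabotropic glutamate receptor 2 (Rattus norvegicus) (on this read-out lower numbers stand for stronger inhibition and higher numbers for weaker inhibition), compound 3 gives the largest of the three numbers: its step from compound 1 is within the scatter (a 1.5-fold higher number from compound 1 to compound 3 (0.17 log units; within the scatter)), while its step from compound 2 lies just beyond it (a 2.4-fold higher number from compound 2 to compound 3 (0.38 log units; beyond the scatter)). The change from bromo to cyano on the ring, a 1.6-fold lower number from compound 1 to compound 2 (0.20 log units; within the scatter), was also small.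

Compound 4, `N[C@]1(C(=O)O)[C@H]2[C@@H](C[C@H]1OCc1cccs1)[C@]2(F)C(=O)O`, differs from compound 3 by thiophen-2-yl in place of 2,6-difluorophenyl on a saturated chain carbon bound to an oxygen on a saturated carbon. Among the compounds with values here, the steps that bear on this are the two earlier aryl swaps at the same place, a 1.5-fold higher number from compound 1 to compound 3 (0.17 log units; within the scatter) and a 2.4-fold higher number from compound 2 to compound 3 (0.38 log units; beyond the scatter), both small. A step of similar size is therefore expected in this assay, most likely toward a somewhat lower number, but possibly none beyond the scatter. Compound 4 is expected to give about 5.5 nM, within a range from 2.5 nM to 12 nM. The expected step is a 1.3-fold lower number from compound 3 to compound 4 (0.11 log units; within the scatter).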

Compound 4, inhibition constant: 8.79 nM
Estimate against measurement, compound 4: 1.6-fold (0.20 log units) below; the range from low to high includes it.
By their numbers in this assay, from the lowest: compounds 2, 1, 3 and 4 (each within the scatter of the next, the first and the last beyond it).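

Thiophen-2-yl, a five-membered aromatic ring with a sulfur atom, can replace the six-membered rings at this position with little effect in this assay: the swap gives a 1.3-fold higher number from compound 3 to compound 4 (0.10 log units; within the scatter) and a 1.9-fold higher number from compound 1 to compound 4 (0.27 log units; within the scatter), so neither the smaller ring nor the sulfur moves the number clearly away from those of compound 1 and compound 3. The one clear gap is a 3.0-fold higher number from compound 2 to compound 4 (0.48 log units; beyond the scatter), and it is modest, which shows that even the widest gap so far among these aromatic groups remains small. Nothing available on these compounds explains that gap. Going by these compounds, all four groups are aromatic rings, so it remains open whether a saturated ring such as cyclohexyl would fit as well. A carboxylic acid or an amine on the ring, or a longer chain carrying it, is equally untested among the compounds shown.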